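From Pyridin-2-yl to 4-Methylphenyl on the Ring Amine

This account rests on a few compounds, and the source may have more. Where it says the series, first, only, none or still open, it means among the compounds named here.

Compound 3 `CC#CC(CC(=O)O)c1ccc(OCc2ccc(C(=O)N3CCN(c4ccccn4)CC3)s2)cc1` gives 138 nM in a functional assay on HEK293 cells for agonist activity at Free fatty acid receptor 1 (Homo sapiens), read by fluorescence and calcium flux (on this read-out lower numbers stand for an effect already at smaller amounts and higher numbers for an effect only at larger amounts of compound), the lowest of the two numbers shown. Compound 2 `CC#CC(CC(=O)O)c1ccc(OCc2ccc(C(=O)N3CCN(C4CCCCC4)CC3)s2)cc1` gives 820 nM, and the step is a 5.9-fold lower number from compound 2 to compound 3 (0.77 log units; beyond the scatter). Compound 1 `CC#CC(CC(=O)O)c1ccc(OCc2ccc(C(=O)N3CCN(C)CC3)s2)cc1` reaches only a limit in this assay, > 5000 nM; the record shows (the limit of > 5000 nM in this assay, at which 1 of the 3 values shown sits). The steps of an at least 6.0-fold lower number from compound 1 to compound 2 (0.78 log units; beyond the scatter) and an at least 36-fold lower number from compound 1 to compound 3 (1.55 log units; beyond the scatter) mark the span of the series. Compound 4 `CC#CC(CC(=O)O)c1ccc(OCc2ccc(C(=O)N3CCN(c4ccc(C)cc4)CC3)s2)cc1` differs from compound 3 in one place: 4-methylphenyl in place of pyridin-2-yl on an amine nitrogen in a ring. Going by the values given here, both groups are aromatic rings on the same ring nitrogen, so the change from a saturated to an aromatic ring seen in a 5.9-fold lower number from compound 2 to compound 3 (0.77 log units; beyond the scatter) does not recur, and no measured step swaps one aromatic ring for another. The expected step is therefore a 1.4-fold higher number from compound 3 to compound 4 (0.16 log units; within the scatter), within the scatter. Compound 4 is estimated at 200 nM, between 70 nM and 600 nM.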

Compound 4, half-maximal effective concentration: 211 nM
For compound 4 the middle estimate is 1.1-fold (0.02 log units) below the measured one, within the range that was stated.
By their numbers in this assay, from the lowest: compounds 3 and 4 (each within the scatter of the next); then compound 2. At a limit, above all of these: compound 1.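

On the amine nitrogen in a ring, 4-methylphenyl and pyridin-2-yl are not told apart in this assay (a 1.5-fold higher number from compound 3 to compound 4 (0.18 log units; within the scatter)), so a hetero atom in the aromatic ring is not needed for a number at this level. The lower number against cyclohexyl now holds for a carbon-only aromatic ring as well (a 3.9-fold lower number from compound 2 to compound 4 (0.59 log units; beyond the scatter)). Compound 1 stands at a limit, so an at least 23-fold lower number from compound 1 to compound 4 (1.37 log units; beyond the scatter) gives only a bound: the limit of > 5000 nM in this assay, at which 1 of the 4 values shown sits.

Open, as far as these compounds go, is how plain phenyl, pyrimidin-2-yl or a fluorine on the phenyl ring would read on this ring nitrogen.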